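Replacing the carboxyethylsulfamoyl group of compound 1 with hydroxymethyl

The compounds below may be only part of what the source reports. "The series", "measured", "known", "first", "only" and "open" are said of these compounds alone.

Compound 1 `CCCCN(C(=O)c1ccc(C(F)(F)F)cc1)c1nnc(-c2ccc(S(=O)(=O)NCCC(=O)O)cc2)s1` gives 99.6 uL/min in an ADME assay on microsomes from liver (Rattus norvegicus) for metabolic stability, read by LC-MS, tested at 0.5 uM (on this read-out higher numbers stand for fast clearance and lower numbers for slow clearance), the second highest of the three numbers seen so far: compound 2 `CCCCN(C(=O)c1ccc(C(F)(F)F)cc1)c1nnc(-c2ccc(F)c3[nH]ccc23)s1` gives 43 uL/min, and compound 3 `CCCCN(C(=O)c1ccc(C(F)(F)F)cc1)c1nnc(-c2ccc(CN(C)C)cc2)s1` gives 539 uL/min. Compound 4 `CCCCN(C(=O)c1ccc(C(F)(F)F)cc1)c1nnc(-c2ccc(CO)cc2)s1` is the next compound in the series; the change from compound 1 is hydroxymethyl in place of (2-carboxyethyl)sulfamoyl on an aromatic carbon. Within the data shown here, the only measured step that bears on this position is a 5.4-fold higher number from compound 1 to compound 3 (0.73 log units; beyond the scatter), where a different small group enters at the same place. The step of a 13-fold higher number from compound 2 to compound 3 (1.10 log units; beyond the scatter) concerns another change and bears only indirectly. A rise beyond the scatter is therefore expected for compound 4, smaller than that seen with compound 3 because of a 5.4-fold higher number from compound 1 to compound 3 (0.73 log units; beyond the scatter). For compound 4 the expected value is 200 uL/min, between 80 uL/min and 500 uL/min, a step of a 2.0-fold higher number from compound 1 to compound 4 (0.30 log units; within the scatter).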

Compound 4, intrinsic clearance in a liver preparation (reported as CLH), per the amount of preparation that the assay uses: 279 uL/min
For compound 4 the middle estimate is 1.4-fold (0.14 log units) below the measured one; the range from low to high includes it.
By their numbers in this assay, from the lowest: compound 2; then compound 1; then compounds 4 and 3 (each within the scatter of the next).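

In this assay, a second small group at this place, hydroxymethyl, also stands clear of (2-carboxyethyl)sulfamoyl, with a 2.8-fold higher number from compound 1 to compound 4 (0.45 log units; beyond the scatter) as the step. Hydroxy in place of dimethylamino on the saturated chain carbon gives a 1.9-fold lower number from compound 3 to compound 4 (0.29 log units; within the scatter), so these two groups are not separated. The group of compound 2, with its five-membered aromatic ring, also stays apart, with a 6.5-fold higher number from compound 2 to compound 4 (0.81 log units; beyond the scatter) as the step, and nothing at hand accounts for these steps.

Open, as far as these compounds go, is where a bare carboxylic acid or a primary amine at this place would fall. Also open, from the compounds shown here alone, is whether a longer chain carrying the hydroxy group would stay with compound 4 or move toward compound 1.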